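The source may report more compounds than this note shows. Statements on the series, on what has been measured and on what is new or still open speak of the compounds shown alone.

Measured compounds and values:

- compound 1, `CC(O)(CSc1ccc(S(F)(F)(F)(F)F)cc1)C(=O)Nc1ccc(S(F)(F)(F)(F)F)cc1`, in a functional assay on VCaP cells (Homo sapiens) for antiproliferative activity, read by propidium iodide staining, with a stated time of 96 h (on this read-out higher numbers stand for weaker inhibition and lower numbers for stronger inhibition), gives 28000 nM
- compound 2, `CC(O)(CSc1ccc(F)cc1)C(=O)Nc1ccc(S(F)(F)(F)(F)F)cc1`, in this assay gives 23000 nM
- compound 3, `CC(O)(CS(=O)(=O)c1ccc(S(F)(F)(F)(F)F)cc1)C(=O)Nc1cccc(S(F)(F)(F)(F)F)c1`, in this assay gives 17200 nM

Compound 2 differs from compound 1 by one fluorine atom in place of a group of 6 heavy atoms (5 fluorine, 1 sulfur; no ring), on an aromatic carbon, and that change gave a 1.2-fold lower number from compound 1 to compound 2 (0.09 log units; within the scatter). Compound 3 carries a different core from compound 1; how the two cores differ is not broken down here. For the measured compounds named here, all three measured values sit close to one another, and none of the steps among them lies beyond the scatter, so no compound can be singled out as stronger or weaker than the others.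

Compound 4, `CC(O)(CS(=O)(=O)c1ccc(F)cc1)C(=O)Nc1cccc(S(F)(F)(F)(F)F)c1`, has not yet been measured. It differs from compound 3 by one fluorine atom in place of a group of 6 heavy atoms (5 fluorine, 1 sulfur; no ring), on an aromatic carbon, the same change, at the same kind of place, that turns compound 1 into compound 2. Because that earlier change gave only a 1.2-fold lower number from compound 1 to compound 2 (0.09 log units; within the scatter), compound 4 is expected to stay close to compound 3, with an estimated step of a 1.1-fold lower number from compound 3 to compound 4 (0.06 log units; within the scatter). The expected value for compound 4 in this assay is therefore 15000 nM, somewhere between 7000 nM and 35000 nM.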

Compound 4, half-maximal inhibitory concentration: 37900 nM
Beside the measured number, compound 4's estimate is 2.5-fold (0.40 log units) below it; the measured number lies above the stated range.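

In this assay, replacing the group of 6 heavy atoms (5 fluorine, 1 sulfur) with fluoro on the core of compound 3 gave a 2.2-fold higher number from compound 3 to compound 4 (0.34 log units; beyond the scatter), a modest step. Set beside the earlier step on the core of compound 1, which lay within the scatter, this shows that the change did not carry over unchanged from one core to the other: the same change on two cores in this assay, a 1.2-fold lower number (0.09 log units; within the scatter) from compound 1 to compound 2 and a 2.2-fold higher number (0.34 log units; beyond the scatter) from compound 3 to compound 4, 2.7-fold (0.43 log units) apart, beyond the scatter of two such steps It does not show which feature of the cores accounts for that gap, and with a single matched pair on each core, it gives no general rule for how the change behaves across this series.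

The compounds shown hold only fluoro or the larger group at this aromatic carbon, so it remains open how a nitrile, a trifluoromethyl or an amine would read there. Going by these compounds, it also remains open whether the gap between the two steps would recur on further cores, or with the same change made on the other aromatic ring.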